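The compounds below may be only part of what the source reports. "The series", "measured", "known", "first", "only" and "open" are said of these compounds alone.

Measured so far:
compound 1 `Oc1ccc(CNc2cc(C(F)(F)F)cc3[nH]ncc23)cc1`: 37%
compound 2 `FC(F)(F)c1cc(NCC2CNC2)c2cn[nH]c2c1`: 10%

In an assay for inhibition of Indoleamine 2,3-dioxygenase 1 (Homo sapiens), with stated times of 10 min and 60 min, tested at 10 uM (on this read-out higher numbers stand for a stronger effect at the one concentration tested and lower numbers for a weaker effect), compound 2 gives the lowest of the two numbers shown; compound 1 stands nearest and higher, the only measured step being a number 27 percentage points lower from compound 1 to compound 2 (beyond the scatter). Compound 3 `FC(F)(F)c1cc(NC[C@@H]2CCCCN2)c2cn[nH]c2c1` differs from compound 2 by piperidin-2-yl in place of azetidin-3-yl on a saturated chain carbon bound to a nitrogen on an aromatic ring. Going by the values given here, that step concerns a different exchange at the same place, so no measured step bears directly on the change to compound 3. For compound 3 a step of a number 7 percentage points higher from compound 2 to compound 3 (within the scatter) is expected, not beyond the scatter. Compound 3 is therefore estimated at 17%, with a range of 0% to 40%.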

Compound 3, a percentage reported as inhibition, at one concentration (the size of the read-out at that concentration, not a potency): 32%
The estimate for compound 3 lay 15 percentage points below the measured number; low and high end bracket the measured number.
By their numbers in this assay, from the lowest: compound 2; then compounds 3 and 1 (each within the scatter of the next).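

In this assay, going from (azetidin-3-yl)methyl to (piperidin-2-yl)methyl gives a number 22 percentage points higher from compound 2 to compound 3 (beyond the scatter), so the read-out at this place depends on which saturated ring is attached. With a number 5 percentage points lower from compound 1 to compound 3 (within the scatter), piperidin-2-yl and 4-hydroxyphenyl cannot be told apart here, so an aromatic ring is not needed at this place for a read-out of this size. Nothing available bears on the reason for either step.

Open, as far as these compounds go, is whether the opposite stereoisomer of piperidin-2-yl reads the same. Also open, from the compounds shown here alone, is how pyrrolidin-2-yl or an open-chain amine would compare at this place.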